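Replacing Pyrimidinyl with Dihydrobenzodioxinyl on the Triazole Nitrogen

This account rests on a few compounds, and the source may have more. Where it says the series, first, only, none or still open, it means among the compounds named here.

Compound 1 `COC1=C(OC)C(=O)C(CCCCCCCCCCn2cc(C[C@H](O)COCCOC[C@@H](O)Cc3ccc(-c4ccccc4)cc3)nn2)=C(C)C1=O`: 600 nM
Compound 2 `O[C@H](COCCOC[C@@H](O)Cc1cn(Cc2cccc(-c3ccccc3)c2)nn1)Cc1ccc(-c2ccccc2)cc1`: 7200 nM
Compound 3 `O[C@H](COCCOC[C@@H](O)Cc1cn(-c2cncnc2)nn1)Cc1ccc(-c2ccccc2)cc1`: > 100000 nM

In a functional assay on HCT-116 cells (Homo sapiens) for inhibition, read by MTT assay, with a stated time of 72 h (a higher number here means a weaker inhibitor of growth, a lower number a stronger inhibitor of growth), compound 1 gives 600 nM and compound 2 gives 7200 nM. For compound 3 this assay reports only a limit, > 100000 nM, so compound 3 stands at the limit of > 100000 nM in this assay, at which 1 of the 3 values shown sits, and no number is known for it. Compound 4 `O[C@H](COCCOC[C@@H](O)Cc1cn(-c2ccc3c(c2)OCCO3)nn1)Cc1ccc(-c2ccccc2)cc1` differs from compound 3 by 2,3-dihydro-1,4-benzodioxin-6-yl in place of pyrimidin-5-yl on an aromatic nitrogen. Going by the values given here, no measured pair shows this change. Compound 4 is expected to move below the limit of compound 3, a step of an at least 3.3-fold lower number from compound 3 to compound 4 (0.52 log units; beyond the scatter) in this assay, taken as beyond the scatter. Compound 4 is estimated at 30000 nM, in the range 8000 nM to 100000 nM.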

Compound 4, concentration for 50% growth inhibition: 16500 nM
Estimate against measurement, compound 4: 1.8-fold (0.26 log units) above; the range from low to high includes it.
By their numbers in this assay, from the lowest: compound 1; then compound 2; then compound 4. At a limit, above all of these: compound 3.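

In this assay, the place on an aromatic nitrogen turns out to respond to the aryl group it carries: 2,3-dihydro-1,4-benzodioxin-6-yl in place of pyrimidin-5-yl gives an at least 6.0-fold lower number from compound 3 to compound 4 (0.78 log units; beyond the scatter). This brings a readable number to a pair whose starting point had none. Compound 3 is only a limit, so the size of this step remains a bound: the limit of > 100000 nM in this assay, at which 1 of the 4 values shown sits.

The compounds shown leave open whether the change follows from the two oxygens of the entering ring or from its carbon framework. A plain phenyl group at this place would help to separate the two.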